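A few compounds are considered here, and "the series" means these few. Any claim that something is new, unique, unknown or untested is made for them only; others in the source may bear on it.

Series as measured in a functional assay on HepG2 cells (Homo sapiens) for antiproliferative activity, read by MTT assay, with a stated time of 48 h; on this read-out higher numbers stand for weaker inhibition and lower numbers for stronger inhibition (compound 4 still open)
- compound 1 `COc1ccc(N(C)c2ccnc(Cl)n2)cc1OCCBr` gives 7720 nM
- compound 2 `COc1ccc(N(C)c2ccnc(Cl)n2)cc1OCCCBr` gives 1240 nM
- compound 3 `COc1ccc(N(C)c2cc(C)nc(C)n2)cc1` gives 824 nM
- compound 4 `COc1ccc(N(C)c2cc(C)nc(C)n2)cc1[N+](=O)[O-]` is not yet measured

Compound 3 (824 nM) sits within the scatter of compound 2 (1240 nM) and clearly under compound 1 (7720 nM). Compound 4 carries nitro in place of hydrogen on an aromatic carbon, ortho to a methoxy group and meta to a large group.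

For the measured compounds named here, only one step has been measured, a 6.2-fold lower number from compound 1 to compound 2 (0.79 log units; beyond the scatter), with bromomethyl in place of bromo on a saturated chain carbon. It bears only loosely on this change: it involves no nitro and lies on a chain, so it offers a scale for a single edit, modest in size, but no direction. Going by the values given here, no nitro compound has been measured. A step no larger than that one is expected in this assay, slightly more likely toward a higher number, with a lower number not excluded. The estimated change is a 1.7-fold higher number from compound 3 to compound 4 (0.23 log units; within the scatter). Compound 4 is estimated at 1400 nM, with an expected range from 300 nM to 6500 nM.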

Compound 4, half-maximal inhibitory concentration: 2990 nM
Estimate against measurement, compound 4: 2.1-fold (0.33 log units) below; low and high end bracket the measured number.
By their numbers in this assay, from the lowest: compounds 3 and 2 (each within the scatter of the next); then compound 4; then compound 1.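

In this assay, nitro in place of hydrogen on an aromatic carbon, ortho to a methoxy group and meta to a large group, gives a 3.6-fold higher number from compound 3 to compound 4 (0.56 log units; beyond the scatter) and so moves toward weaker inhibition. This is the only measured edit at this position, and it shows that the series is not indifferent to what sits there: the step lies beyond the scatter. Between these two groups, hydrogen gives the stronger inhibition, but nothing measured on these compounds accounts for the step.

On these data alone, whether the change in number belongs to nitro itself or would follow any group on this carbon remains open, since a single substituent gives only one point. An amine, a fluorine atom or a nitrile on the same carbon would show whether hydrogen stays ahead of other groups there.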